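Compound 3 loses the chloro of compound 1

A few compounds are considered here, and "the series" means these few. Any claim that something is new, unique, unknown or untested is made for them only; others in the source may bear on it.

Among the measured compounds shown here, in an ADME assay (liver, Mus musculus) for metabolic stability, read by LC-MS, using microsomes, tested at 1 uM (a higher number here means that the compound lasts longer, a lower number that the compound disappears faster), compound 1 (`CN(C)CCCN/C(=N\c1ccnc2cc(Cl)ccc12)c1ccc(Cl)cc1`) gives 0.583 h, the only exact number available so far. Compound 2 (`C/C(=N/c1ccnc2cc(Cl)ccc12)NCCCCN1CCCCC1`) is reported as > 1 h, which is a limit of the assay and not a number. The next compound to be tested is compound 3 (`CN(C)CCCN/C(=N\c1ccnc2cc(Cl)ccc12)c1ccccc1`), which differs from compound 1 in one place: hydrogen in place of chloro on an aromatic carbon. It has hydrogen in place of chloro on an aromatic carbon, para to a large group, so that 4-chlorophenyl becomes phenyl. For the measured compounds named here, no measured pair shows what this change does in this assay, so no shift beyond the usual scatter is expected, in either direction. The estimate therefore stays close to compound 1 at 0.583 h. The expected step of a 1.2-fold lower number from compound 1 to compound 3 (0.07 log units; within the scatter) is estimated to remain within that scatter. For compound 3 the expected half-life is 0.5 h, with an estimated range of 0.25 h to 1 h.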

Compound 3, half-life: 0.867 h
For compound 3 the middle estimate is 1.7-fold (0.24 log units) below the measured one; the measured number falls inside the stated range.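

In this assay, the change from 4-chlorophenyl to phenyl now has a measured pair, with a 1.5-fold higher number from compound 1 to compound 3 (0.17 log units; within the scatter). On this aromatic carbon, para to a large group, hydrogen and chloro therefore cannot be told apart by half-life, and the chloro is not shown to be needed to keep the read-out where it stands. Compound 2 remains a limit of the assay and not a number, and it differs from compound 1 in more than one place, so it offers no comparison for this change: the limit of > 1 h in this assay, at which 1 of the 3 values shown sits.

On these data alone, whether fluoro, methoxy or a carboxylic acid on that same carbon would move the half-life beyond the scatter remains open. Among the compounds shown here, also open is what a longer chain in place of the one carried by compound 1 would do.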